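A few compounds are considered here, and "the series" means these few. Any claim that something is new, unique, unknown or untested is made for them only; others in the source may bear on it.

Two compounds share one core and differ only in the group carried by a sulfonyl sulfur. Compound 1 `CNC(=O)NCCS(=O)(=O)NC(=O)c1ccc(Nc2nc(NC3(c4ccc(Cl)cc4)CC3)nc(OCC(F)(F)F)n2)cc1` gives 97% in an ADME assay on microsomes from liver (Homo sapiens) for metabolic stability, with a stated time of 10 min; on this read-out lower numbers stand for a less stable compound and higher numbers for a more stable compound. Within the data shown here, compound 2 `CN(C)S(=O)(=O)NC(=O)c1ccc(Nc2nc(NC3(c4ccc(Cl)cc4)CC3)nc(OCC(F)(F)F)n2)cc1` gives 86% in this assay, the lower of the two numbers, and the single change between them, a number 11 percentage points lower from compound 1 to compound 2 (beyond the scatter), lies beyond the scatter. Compound 3 `Cc1ccccc1S(=O)(=O)NC(=O)c1ccc(Nc2nc(NC3(c4ccc(Cl)cc4)CC3)nc(OCC(F)(F)F)n2)cc1` has not yet been measured. Relative to compound 2 the change is 2-methylphenyl in place of dimethylamino on a sulfonyl sulfur. Among the measured compounds shown here, the only measured step that touches this position is a number 11 percentage points lower from compound 1 to compound 2 (beyond the scatter), a modest drop when one group was exchanged for another on the same sulfonyl sulfur. For the measured compounds named here, no measured step involves a 2-methylphenyl group at this place, so the expectation rests on that one comparison alone. The step of a number 8 percentage points lower from compound 2 to compound 3 (within the scatter) is expected to be small, most likely a modest further drop, though it could also fall within the scatter. Compound 3 is therefore estimated to reach 78% in this assay, with a plausible range from 58% to 95%.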

Compound 3, percent of the compound remaining: 100%
The estimate for compound 3 lay 22 percentage points below the measured number, outside the stated range (above it).
By their numbers in this assay, from the lowest: compound 2; then compounds 1 and 3 (each within the scatter of the next).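

In this assay this position on the sulfonyl sulfur can now be seen moving in both directions: the earlier pair showed only a drop, whereas 2-methylphenyl in place of dimethylamino gives a number 14 percentage points higher from compound 2 to compound 3 (beyond the scatter). The new group, with its six-membered aromatic ring of carbon only, also matches the very different 2-((methylcarbamoyl)amino)ethyl chain, as the comparison with compound 1 gives a number 3 percentage points higher from compound 1 to compound 3 (within the scatter) and so cannot separate the two. Of the three groups on this sulfur, dimethylamino is therefore the only one that stands apart, while a ring and a chain share the same upper level. Nothing available gives a reason for this difference.

The compounds shown leave open whether the methyl on the ring matters, which a plain phenyl group would test, and whether a small methyl group on the sulfur would sit with dimethylamino or with the other two. They also leave open how a cyclic amine such as morpholine or a chain ending in a carboxylic acid would fare at this position.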